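The compounds below may be only part of what the source reports. "The series", "measured", "known", "first", "only" and "open" are said of these compounds alone.

Working notes on the series. All three measured compounds share one core and differ in the chain carried on the ring oxygen. Compound 1, `CC(=O)c1cc(CO)c(OCCCCCCC#N)cc1O`, gives 40% in an assay on isolated protein for inhibition of leukotriene B4 receptor 1 (Homo sapiens), tested at 10 uM; a lower number here means less inhibition, a higher number more inhibition at the concentration tested (going by the name of the read-out). Compound 2, `C=CCc1cc(C(C)=O)c(O)cc1OCCCC#N`, gives 47% in this assay. Compound 3, `CCc1cc(C(C)=O)c(O)cc1OCCCC(C)(C)C(=O)O`, gives 89% in this assay. On these three numbers compound 2 stands second highest; its nearest neighbour is compound 1, lower by a margin that lies within the usual scatter, and its furthest is compound 3, higher by a margin that lies well beyond the scatter. Compound 4, `C=CCc1cc(C(C)=O)c(O)cc1OCCCCO`, has not been measured. It differs from compound 2 in one place: hydroxymethyl in place of cyano on a saturated chain carbon, three bonds along the chain from an oxygen on an aromatic ring. Among the compounds with values here, no measured pair in the set shows this particular change, so nothing among the three numbers directly tells what the step should be; the one large difference seen, compound 3 against compound 2, carries a different group on the chain and cannot be transferred. In this assay no step beyond the scatter is expected, and the estimated step of a number 3 percentage points higher from compound 2 to compound 4 (within the scatter) leans only slightly upward. Compound 4 is therefore estimated at 50%, with the expected range running from 30% to 70%.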

Compound 4, a percentage reported as inhibition, at one concentration (the size of the read-out at that concentration, not a potency): 48%
Compound 4: middle estimate off by 2 percentage points, on the high side; the range from low to high includes it.
By their numbers in this assay, from the lowest: compounds 1, 2 and 4 (each within the scatter of the next); then compound 3.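

In this assay, within the data shown here, hydroxymethyl in place of cyano on a saturated chain carbon, three bonds along the chain from an oxygen on an aromatic ring, comes with a number 1 percentage points higher from compound 2 to compound 4 (within the scatter), the first step that can be read at this position. The change removes a triple bond and brings in a hydrogen-bond donor, yet the read-out at the single tested concentration does not move beyond the scatter, so at this position, on the core of compound 2, the two chain ends cannot be told apart in this measurement. Nothing available bears on why these two chain ends read alike.

Compound 3 gives 89% but differs from compound 4 in more than one place, so the step between them says nothing about any single group. Open, therefore, is what a carboxylic acid, an amine or a longer chain would give at this position with the rest of compound 4 held fixed, and whether any of them would produce a step beyond the scatter.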